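The source may hold more compounds than are shown below. What is called first, only, known or untested is meant among the compounds shown, and "the series" means these compounds.

Working notes on the series. Compound 1 `COc1ccccc1NC(=S)N/N=C/c1ccc2ccccc2n1` and compound 2 `N#Cc1ccc(NC(=S)N/N=C/c2ccc3ccccc3n2)cc1` share one core and differ only at the amide-type nitrogen. In a functional assay on SGC-7901 cells (Homo sapiens) for antiproliferative activity, read by sulforhodamine B assay, with a stated time of 72 h (on this read-out higher numbers stand for weaker inhibition and lower numbers for stronger inhibition), compound 1 gives > 100000 nM, which is a limit of the assay (the limit of > 100000 nM in this assay, at which 1 of the 2 values shown sits). In this assay, among the compounds with values here, compound 2 gives 23700 nM, the only plain number so far. Within the data shown here, the single measured step is an at least 4.2-fold lower number from compound 1 to compound 2 (0.62 log units; beyond the scatter). Compound 3 `NC(=S)N/N=C/c1ccc2ccccc2n1` removes the aryl group altogether: hydrogen in place of 4-cyanophenyl on an amide-type nitrogen. Among the measured compounds shown here, that one step is the only guide, and it points to the aryl group carrying the activity, so the expected step of a 2.1-fold higher number from compound 2 to compound 3 (0.32 log units; beyond the scatter) runs toward a higher number. Compound 3 is estimated at 50000 nM, range 8000 nM to 100000 nM, with a real chance of only a limit.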

Compound 3, half-maximal inhibitory concentration: 32700 nM
Compound 3: middle estimate off by 1.5-fold (0.18 log units), on the high side; the measured number falls inside the stated range.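

In this assay, the step of a 1.4-fold higher number from compound 2 to compound 3 (0.14 log units; within the scatter) shows that hydrogen on the amide-type nitrogen serves as well as 4-cyanophenyl, so an aryl group is not required there for this level of activity. The step of an at least 3.0-fold lower number from compound 1 to compound 3 (0.48 log units; beyond the scatter) ties the weak result of compound 1 to the 2-methoxyphenyl group rather than to the aryl position as such. The size of that step is only a bound, since compound 1 stands at a limit of the assay: the limit of > 100000 nM in this assay, at which 1 of the 3 values shown sits.

Open, going by these compounds, is whether methyl or a longer chain on this nitrogen matches hydrogen. Also open, on these data alone, is whether 4-methoxyphenyl behaves like 2-methoxyphenyl or like 4-cyanophenyl.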